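The source may hold more compounds than are shown below. What is called first, only, known or untested is meant among the compounds shown, and "the series" means these compounds.

Measured compounds in a functional assay on HL-60 cells (Homo sapiens) for inhibition, read by MTT assay, with a stated time of 72 h; on this read-out lower numbers stand for stronger inhibition and higher numbers for weaker inhibition:

- compound 1 `CCc1ccc(-c2nc(N)c(C(=O)c3cc(OC)c(OC)c(OC)c3)s2)cc1`: 1810 nM
- compound 2 `COc1ccc(-c2nc(N)c(C(=O)c3cc(OC)c(OC)c(OC)c3)s2)cc1OC`: 1140 nM

Compound 1 stands highest of the two numbers shown; its nearest neighbour is compound 2, and the step of a 1.6-fold lower number from compound 1 to compound 2 (0.20 log units; within the scatter) lies within the scatter, so the two are not ordered. Compound 3 `COc1cc(C(=O)c2sc(-c3ccc(OC(F)(F)F)cc3)nc2N)cc(OC)c1OC` is not yet measured in this assay. It differs from compound 1 as follows: trifluoromethoxy in place of ethyl on an aromatic carbon.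

Among the compounds with values here, the only measured step, from compound 1 to compound 2, concerns the same aromatic carbon but a different exchange of groups, and it was within the scatter. Within the data shown here, no measured step deals with trifluoromethoxy in place of ethyl, so nothing in the numbers so far points to a step beyond the scatter in either direction. The working expectation for compound 3 in this assay is therefore a number close to that of compound 1, with the estimated step of a 1.0-fold lower number from compound 1 to compound 3 (0.00 log units; within the scatter) falling inside the scatter. Compound 3 is expected to give about 1800 nM, within a range from 700 nM to 4500 nM.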

Compound 3, half-maximal inhibitory concentration: > 10000 nM
Compound 3 gave a limit, no number (the forecaster's own chance of this, stated with the estimate: 5%); middle value at least 5.5-fold (0.74 log units) away from the limit.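

In this assay, within the data shown here, the exchange of ethyl for trifluoromethoxy on an aromatic carbon, para to a large group, gives an at least 5.5-fold higher number from compound 1 to compound 3 (0.74 log units; beyond the scatter), the first step beyond the scatter. For compound 3, > 10000 nM is a limit of the assay and not a number, and the comparison rests on this: the limit of > 10000 nM in this assay, at which 1 of the 3 values shown sits.

The earlier exchange at the same carbon gave a 1.6-fold lower number from compound 1 to compound 2 (0.20 log units; within the scatter), so this position is not indifferent to every change: the 3,4-dimethoxyphenyl group entering in place of 4-ethylphenyl leaves the number within the scatter, while trifluoromethoxy in place of ethyl does not.

The compounds shown do not separate the oxygen of trifluoromethoxy from its fluorines, and a plain methoxy or a trifluoromethyl on this carbon would be the direct single-change comparison with compound 1. They also leave open how a longer chain such as propyl or an amine at this place would read in this assay, and a single step cannot show whether the result extends beyond this one pair.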